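This account rests on a few compounds, and the source may have more. Where it says the series, first, only, none or still open, it means among the compounds named here.

Within the data shown here, only two compounds have numbers so far. In a functional assay on HepG2 cells (Homo sapiens) for cytotoxicity, read by sulforhodamine B assay, with a stated time of 48 h (a higher number here means a weaker inhibitor, a lower number a stronger inhibitor), compound 1 (`COc1ccc(/C=C/C(=O)c2ccc(NC(C)=O)c(-c3ccc(F)cc3)c2)cc1OC`) gives 5630 nM and compound 2 (`COc1cccc(/C=C/C(=O)c2cccc(-c3cccc(F)c3)c2)c1OC`) gives 9200 nM. These two values lie within the usual scatter of each other, so the numbers do not separate compound 2 from compound 1, even though the two structures differ in more than one place.

Compound 3 (`COc1ccccc1/C=C/C(=O)c1cccc(-c2cccc(F)c2)c1`) has not yet been measured in this assay. It departs from compound 2 at one place only: hydrogen in place of methoxy on an aromatic carbon. In words, hydrogen stands in place of methoxy on an aromatic carbon.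

Among the measured compounds shown here, no two measured compounds differ in a single place, so the data hold no direct precedent for this change and give no direction for it. The expectation therefore rests on compound 2 at 9200 nM, with no shift beyond the scatter foreseen. The estimated step, a 1.1-fold higher number from compound 2 to compound 3 (0.04 log units; within the scatter), is expected to stay small. For compound 3 the expected value is 10000 nM, within an estimated range from 4000 nM to 25000 nM.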

Compound 3, half-maximal inhibitory concentration: 15400 nM
Beside the measured number, compound 3's estimate is 1.5-fold (0.19 log units) below it; the range from low to high includes it.
By their numbers in this assay, from the lowest: compounds 1, 2 and 3 (each within the scatter of the next, the first and the last beyond it).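

Among these compounds, this is the first comparison between two compounds that differ in one place. In this assay, hydrogen in place of methoxy on an aromatic carbon, ortho to a methoxy group and meta to a large group, gives a 1.7-fold higher number from compound 2 to compound 3 (0.22 log units; within the scatter). The exchange takes away a methoxy group of 2 heavy atoms without moving the read-out beyond the scatter, so this single step gives no sign that the group at this position matters for the effect on these cells, and nothing measured here offers an explanation for that outcome.

The compounds shown leave open whether a different group on this aromatic carbon, such as an amine, a hydroxyl group or a chlorine atom, would give a number beyond the scatter of compound 2 and compound 3. They also leave open whether hydrogen in place of methoxy would read the same way on the core of compound 1, which differs from compound 2 in more than one place.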